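Amide aryl variation in a dihydropyridine series: compound 3

The source may hold more compounds than are shown below. What is called first, only, known or untested is meant among the compounds shown, and "the series" means these compounds.

Two amide analogues of the shared core have been measured so far. Compound 1 `CCOC(=O)C1=C(C)NC(C)=C(C(=O)OCC)C1c1ccc(OCC(=O)NCc2ccccc2)cc1` gives 8.33% in a functional assay on the whole organism (strain Wistar) for inhibition, with Rattus norvegicus as the target, read by paw edema, with stated times of 30 min and 0.5 h, at a dose of 20 mg/kg; a higher number here means more inhibition at the dose given (going by the name of the read-out), a lower number less inhibition. Compound 2 `CCOC(=O)C1=C(C)NC(C)=C(C(=O)OCC)C1c1ccc(OCC(=O)Nc2c(C)cccc2C)cc1` gives 15.9% in this assay; the step of a number 7.6 percentage points higher from compound 1 to compound 2 (within the scatter) lies within the scatter, so the two compounds are not separated by these numbers.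

Compound 3 `CCOC(=O)C1=C(C)NC(C)=C(C(=O)OCC)C1c1ccc(OCC(=O)Nc2ccc(C)cc2)cc1` is next. The change from compound 2 is 4-methylphenyl in place of 2,6-dimethylphenyl on an amide-type nitrogen. Within the data shown here, no measured step touches this difference directly; the one step known, a number 7.6 percentage points higher from compound 1 to compound 2 (within the scatter), also varied the group on the amide-type nitrogen and stayed within the scatter. On that basis no step beyond the scatter is expected for compound 3 in this assay, with a number 2.9 percentage points lower from compound 2 to compound 3 (within the scatter) as the expected change from compound 2. Compound 3 is therefore estimated at 13%, with a range of 3% to 25%.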

Compound 3, a percentage reported as inhibition, in the whole organism at one dose (the size of the read-out at that dose, not a potency): 43.9%
Compound 3: middle estimate off by 30.9 percentage points, on the low side; the whole stated range lies below it.
By their numbers in this assay, from the lowest: compounds 1 and 2 (each within the scatter of the next); then compound 3.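

In this assay, among these compounds, a number 28 percentage points higher from compound 2 to compound 3 (beyond the scatter) and a number 35.6 percentage points higher from compound 1 to compound 3 (beyond the scatter) are the first steps at this position to go beyond the scatter. The group on the amide-type nitrogen can therefore separate compounds in this series, which the earlier step between compound 1 and compound 2 could not show. Compound 3, with 4-methylphenyl, stands apart from both the benzyl and the 2,6-dimethylphenyl analogues, while those two remain within the scatter of each other. Nothing at hand bears on the origin of these steps.

The compounds shown leave open whether the step from compound 2 to compound 3 follows the number of methyl groups or where they sit on the ring. On these data alone, how an unsubstituted phenyl or a phenethyl group on the same nitrogen would compare also remains open, as does whether the order holds at other doses.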